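The source may hold more compounds than are shown below. What is called first, only, known or untested is meant among the compounds shown, and "the series" means these compounds.

Of the compounds shown here, three sharing one core have been tested in a functional assay on DU-145 cells (Homo sapiens) for inhibition, read by trypan blue exclusion, with a stated time of 72 h (on this read-out lower numbers stand for stronger inhibition and higher numbers for weaker inhibition), and they differ only in the group on the sulfonyl sulfur. Compound 1 `Cn1c(=O)c(S(=O)(=O)c2ccc(C(=O)O)cc2)cc2cnc(Nc3ccc4[nH]ccc4c3)nc21` with 4-carboxyphenyl gives 10000 nM as its number, and compound 2 `Cn1c(=O)c(S(=O)(=O)Cc2ccc(F)cc2)cc2cnc(Nc3ccc4[nH]ccc4c3)nc21` with 4-fluorobenzyl gives 30000 nM as its number. Compound 3 `Cn1c(=O)c(S(=O)(=O)c2ccc(Cl)cc2)cc2cnc(Nc3ccc4[nH]ccc4c3)nc21` with 4-chlorophenyl stands lowest of the three at 250 nM on this scale, so it shows the strongest inhibition so far.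

Compound 4 `Cn1c(=O)c(S(=O)(=O)c2ccc(Br)cc2)cc2cnc(Nc3ccc4[nH]ccc4c3)nc21` alters compound 3 in one place: bromo in place of chloro on an aromatic carbon describes the change, which puts bromo in place of chloro on an aromatic carbon, para to a large group.

Within the data shown here, two measured steps touch this group. Chloro in place of carboxy gave a 40-fold lower number from compound 1 to compound 3 (1.60 log units; beyond the scatter) as a large step, and 4-chlorophenyl in place of 4-fluorobenzyl gave a 120-fold lower number from compound 2 to compound 3 (2.08 log units; beyond the scatter) as another large one. Neither step swaps one halogen for another, so the data hold no direct measure of this change, and both replaced far more than a single halogen atom. A step beyond the scatter is therefore not expected, and the estimate is a 1.1-fold higher number from compound 3 to compound 4 (0.05 log units; within the scatter) at most in size. In this assay compound 4 is estimated at 280 nM with a range from 110 nM to 700 nM as the expected span.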

Compound 4, half-maximal inhibitory concentration: 5000 nM
Compound 4: middle estimate off by 18-fold (1.25 log units), on the low side, and the stated range ends below it.
By their numbers in this assay, from the lowest: compound 3; then compounds 4 and 1 (each within the scatter of the next); then compound 2.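

In this assay, bromo in place of chloro on an aromatic carbon, para to a large group, gives a 20-fold higher number from compound 3 to compound 4 (1.30 log units; beyond the scatter) as a large step, even though one heavy atom simply replaces another and neither side counts any hydrogen-bond donors or acceptors. The low number of compound 3 therefore does not extend to every halogen in this place: bromo in place of carboxy gives a 2.0-fold lower number from compound 1 to compound 4 (0.30 log units; within the scatter) and 4-bromophenyl in place of 4-fluorobenzyl gives a 6.0-fold lower number from compound 2 to compound 4 (0.78 log units; beyond the scatter) as only a modest step, so among these compounds the large gain appears with chloro alone. Nothing shown here offers a reason for this sharp difference between two halogens.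

On these data alone, how a fluoro, a methyl or a methoxy in this same place would read remains open, so it cannot yet be said whether chloro stands alone or compound 4 is the exception. Also open, as far as these compounds go, is whether 4-chlorobenzyl on the sulfonyl sulfur would keep the low number seen with 4-chlorophenyl or fall back towards that of the 4-fluorobenzyl compound.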